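The source may report more compounds than this note shows. Statements on the series, on what has been measured and on what is new or still open speak of the compounds shown alone.

Among the measured compounds shown here, in a functional assay on HL-60 cells (Homo sapiens) for antiproliferative activity, read by sulforhodamine B assay, with a stated time of 72 h (on this read-out higher numbers stand for weaker inhibition and lower numbers for stronger inhibition), compound 2 (`S=C(NCc1ccccc1)N/N=C/c1ccc2ccccc2n1`) gives 21900 nM, the higher of the two numbers so far, while compound 1 (`N#Cc1ccc(NC(=S)N/N=C/c2ccc3ccccc3n2)cc1`) gives 4660 nM. Compound 3 (`S=C(N/N=C/c1ccc2ccccc2n1)Nc1cccc(Br)c1`) keeps the shared core but carries 3-bromophenyl in place of benzyl on an amide-type nitrogen. For the measured compounds named here, the one measured step that bears on this is a 4.7-fold higher number from compound 1 to compound 2 (0.67 log units; beyond the scatter), with benzyl in place of 4-cyanophenyl. Going by the values given here, compound 3 reverses that kind of change, although no bromine-bearing compound has been measured yet. A step of similar size toward a lower number is therefore expected in this assay, an estimated 4.4-fold lower number from compound 2 to compound 3 (0.64 log units; beyond the scatter). Compound 3 is expected at about 5000 nM, within a range of 1500 nM to 16000 nM.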

Compound 3, half-maximal inhibitory concentration: 53800 nM
Compound 3: the middle estimate sits 11-fold (1.03 log units) below what was measured, outside the stated range (above it).
By their numbers in this assay, from the lowest: compound 1; then compound 2; then compound 3.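

Replacing benzyl with a substituted phenyl ring on this amide-type nitrogen does not by itself lower the number: 3-bromophenyl gives a 2.5-fold higher number from compound 2 to compound 3 (0.39 log units; beyond the scatter), the opposite direction to the step between 4-cyanophenyl and benzyl. The two substituted phenyl rings also lie far apart, with a 12-fold higher number from compound 1 to compound 3 (1.06 log units; beyond the scatter), so the result at this position depends on more than having a phenyl ring in place of benzyl. No measurement at hand explains this gap. From the compounds shown here alone, whether plain phenyl, 4-bromophenyl or an amine-bearing phenyl ring would sit nearer compound 1 or compound 3 remains open.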